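This account rests on a few compounds, and the source may have more. Where it says the series, first, only, none or still open, it means among the compounds named here.

Measured so far:
compound 1 `O=C(O)CCCSCCN1C(=O)OC[C@@H]1/C=C/[C@@H](O)Cc1ccccc1` – in a functional assay on CHO cells for agonist activity at prostaglandin E2 receptor EP4 subtype (Rattus norvegicus), read by cAMP accumulation and immunoassay, with a stated time of 10 min (on this read-out higher numbers stand for an effect only at larger amounts of compound and lower numbers for an effect already at smaller amounts), compound 1 gives 36 nM
compound 2 `CCCc1cccc(C[C@H](O)/C=C/[C@H]2CSC(=O)N2CCSCCCC(=O)O)c1` – in this assay compound 2 gives 6.1 nM

Among the compounds with values here, compound 1 holds the highest of the two numbers; compound 2 shows a lower number, beyond the scatter, but its structure differs from compound 1 in more than one place, so no single step is read from that pair. Compound 3 `CCc1cccc(C[C@H](O)/C=C/[C@H]2COC(=O)N2CCSCCCC(=O)O)c1` differs from compound 1 by ethyl in place of hydrogen on an aromatic carbon. Compound 2 carries a propyl on its aromatic ring together with a different core, so the ethyl alone is not isolated. A moderate downward step is expected as a 2.6-fold lower number from compound 1 to compound 3 (0.41 log units; beyond the scatter). Compound 3 is estimated at 14 nM, range 4 nM to 45 nM.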

Compound 3, half-maximal effective concentration: 18 nM
Beside the measured number, compound 3's estimate is 1.3-fold (0.11 log units) below it; measured number inside the range.
By their numbers in this assay, from the lowest: compound 2; then compounds 3 and 1 (each within the scatter of the next).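

Ethyl on this aromatic carbon, meta to a large group, gives a 2.0-fold lower number from compound 1 to compound 3 (0.30 log units; within the scatter) in this assay, the first single-place step in the series, so this position accepts the two added carbons without a change beyond the scatter. Within the data shown here, compound 2 differs from compound 1 and compound 3 in more than one place, so no step to it can be read. No measured evidence bears on the reason for this result. Open, from the compounds shown here alone, is how a methoxy, a chlorine or a propyl at this position would read on the core of compound 1.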